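The compounds below may be only part of what the source reports. "The series", "measured", "known", "first", "only" and "open" are said of these compounds alone.

Measured so far:
compound 1 `CSc1nc2n(n1)C(c1ccc(O)cc1O)C([N+](=O)[O-])=NN2`: 201000 nM
compound 2 `O=[N+]([O-])C1=CNc2ncnn2C1c1ccc(O)c(O)c1`: 368000 nM

In an ADME assay on MDCK cells (Canis lupus familiaris) for cytotoxicity (a lower number here means that less compound is tolerated, a higher number that more compound is tolerated), compound 2 gives 368000 nM. For the measured compounds named here, the only companion is compound 1, whose value in this assay of 201000 nM lies within the usual scatter of that of compound 2, so the two show no separable difference. Compound 3 `O=[N+]([O-])C1=CNc2nc(-c3ccco3)nn2C1c1ccc(O)c(O)c1` carries the change (furan-2-yl in place of hydrogen on an aromatic carbon). Nothing measured here shows what such an addition does, so the step from compound 2 to compound 3 in this assay is expected to be small, toward a somewhat lower number, possibly no more than the scatter: a 1.8-fold lower number from compound 2 to compound 3 (0.26 log units; within the scatter). Compound 3 is therefore estimated at 200000 nM, in a range from 80000 nM to 450000 nM.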

Compound 3, half-maximal cytotoxic concentration: > 1200000 nM
Compound 3 ended at the assay's limit (the forecaster's own chance of this, stated with the estimate: 25%); middle value at least 6.0-fold (0.77 log units) from the limit.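

Furan-2-yl in place of hydrogen on the aromatic carbon between two ring nitrogen atoms gives an at least 3.2-fold higher number from compound 2 to compound 3 (0.51 log units; beyond the scatter) in this assay, so this position accepts a five-membered aromatic ring with more compound tolerated, not less. Compound 3 reads > 1200000 nM, which is a limit of the assay and not a number. The step can therefore be read only as a minimum because of that limit: the limit of > 1200000 nM in this assay, at which 1 of the 3 values shown sits.

The compounds shown leave open whether an amine, a phenyl ring or a methyl group on this carbon would move the number the same way.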